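Anilino substitution and potency across a shared core

The source may hold more compounds than are shown below. What is called first, only, known or untested is meant among the compounds shown, and "the series" means these compounds.

Measured in a functional assay on MGC-803 cells (Homo sapiens) for inhibition, read by MTT assay, with a stated time of 72 h; a higher number here means a weaker inhibitor, a lower number a stronger inhibitor:
Compound 1 `N#Cc1c(Nc2cccc(C(F)(F)F)c2)nc(SCc2cn(Cc3ccccc3Cl)nn2)nc1-c1ccccc1`: 22800 nM
Compound 2 `N#Cc1c(Nc2ccccc2F)nc(SCc2cn(Cc3ccccc3Cl)nn2)nc1-c1ccccc1`: 7580 nM
Compound 3 `N#Cc1c(Nc2ccccc2)nc(SCc2cn(Cc3ccccc3Cl)nn2)nc1-c1ccccc1`: > 64000 nM, which is a limit of the assay and not a number.

For compound 3 only a limit is known; it stands at the limit of > 64000 nM in this assay, at which 1 of the 3 values shown sits. Compound 4 `Cc1ccc(Nc2nc(SCc3cn(Cc4ccccc4Cl)nn3)nc(-c3ccccc3)c2C#N)cc1` differs from compound 3 by methyl in place of hydrogen on an aromatic carbon. Among the compounds with values here, two measured steps bear on this place on the anilino ring, and both end at compound 3: an at least 2.8-fold higher number from compound 1 to compound 3 (0.44 log units; beyond the scatter) and an at least 8.4-fold higher number from compound 2 to compound 3 (0.92 log units; beyond the scatter). Both run the same way, so putting a group back onto that ring is expected to give a lower number in this assay, though the limit at compound 3 leaves the size of the step open. Compound 4 is therefore expected at 40000 nM, within 15000 nM to 100000 nM. This estimate means an expected at least 1.6-fold lower number from compound 3 to compound 4 (0.20 log units; that floor lies within the scatter).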

Compound 4, half-maximal inhibitory concentration: 7190 nM
Compound 4: middle estimate off by 5.6-fold (0.75 log units), on the high side; measured number below the stated range.
By their numbers in this assay, from the lowest: compounds 4 and 2 (each within the scatter of the next); then compound 1. At a limit, above all of these: compound 3.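

In this assay, from the compounds shown here alone, a single methyl, para to a large group, is enough to move the anilino compound off its limit: the step reads an at least 8.9-fold lower number from compound 3 to compound 4 (0.94 log units; beyond the scatter), and its size stays open because the figure for compound 3 is a limit and not a number. 4-Methylphenyl and 2-fluorophenyl cannot be told apart, with a 1.1-fold lower number from compound 2 to compound 4 (0.02 log units; within the scatter), while 4-methylphenyl and 3-(trifluoromethyl)phenyl do separate, with a 3.2-fold lower number from compound 1 to compound 4 (0.50 log units; beyond the scatter).

Each substituted compound differs in both group and ring place, so the two effects remain unseparated. Going by these compounds, how an amine, a carboxylic acid or a longer chain would behave at this place remains open.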